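Notes on the step from compound 2 to compound 3

The source may hold more compounds than are shown below. What is called first, only, known or untested is meant among the compounds shown, and "the series" means these compounds.

- compound 1 `COc1cccc(C(=O)Nc2nnc(/C=C/c3cc(OC)c(OC)c(OC)c3Br)s2)c1`: 120 nM
- compound 2 `COc1cc(/C=C/c2nnc(NC(=O)c3ccc(Br)cc3)s2)c(Br)c(OC)c1OC`: 200 nM

For the measured compounds named here, in a functional assay on HepG2 cells (Mus musculus) for antiproliferative activity against HepG2 (Homo sapiens), read by MTT assay, with a stated time of 48 h (a lower number here means a stronger inhibitor, a higher number a weaker inhibitor), compound 2 gives 200 nM and stands within the scatter of compound 1, the only other measured compound. The next compound is compound 3 `COc1cc(/C=C/c2nnc(NC(=O)c3cccc(Cl)c3)s2)c(Br)c(OC)c1OC`, which carries the change 3-chlorophenyl in place of 4-bromophenyl on a carbonyl carbon. Going by the values given here, one measured step bears on this, as it changes the group at the same place: a 1.7-fold higher number from compound 1 to compound 2 (0.22 log units; within the scatter). Among the compounds with values here, that step stays within the scatter, but it is a single step, and no measured compound carries 3-chlorophenyl. No shift beyond the scatter is therefore expected in this assay, and no direction is favoured. The expected step is a 1.2-fold lower number from compound 2 to compound 3 (0.07 log units; within the scatter). The estimate for compound 3 is 170 nM, with an expected range of 80 nM to 360 nM.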

Compound 3, half-maximal inhibitory concentration: 150 nM
Compound 3: middle estimate off by 1.1-fold (0.05 log units), on the high side; the range from low to high includes it.
By their numbers in this assay, from the lowest: compounds 1, 3 and 2 (each within the scatter of the next).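

In this assay, 3-chlorophenyl in place of 4-bromophenyl on the carbonyl carbon gives a 1.3-fold lower number from compound 2 to compound 3 (0.12 log units; within the scatter) and so adds a third aromatic group at this place without a shift beyond the scatter. Chloro in place of methoxy on an aromatic carbon gives a 1.3-fold higher number from compound 1 to compound 3 (0.10 log units; within the scatter) and is likewise within the scatter, so this assay does not separate 3-methoxyphenyl, 4-bromophenyl and 3-chlorophenyl. No supporting data are available to account for these small steps.

From the compounds shown here alone, all three groups at this place are singly substituted phenyl groups, so the effect of an amine or a carboxylic acid on that phenyl, or of a short alkyl chain in its place, remains open. Also open, going by these compounds, is the separate contribution of halogen identity and halogen placement, as 4-bromophenyl and 3-chlorophenyl differ in both.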